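The source may hold more compounds than are shown below. What is called first, only, known or untested is meant among the compounds shown, and "the series" means these compounds.

In a functional assay on HCT-116 cells (Homo sapiens) for inhibition, read by colorimetric assay, with a stated time of 3 days (a lower number here means a stronger inhibitor, a higher number a weaker inhibitor), compound 1 (`OC(O)(c1c(F)c(F)c(-n2cc(-c3ccccc3)nn2)c(F)c1F)C(F)(F)F`) gives > 100000 nM, which is a limit of the assay and not a number. So there is no exact starting value for this step. Within the data shown here, the only true number so far belongs to compound 2 (`O=C(CCCCCCNC(=O)C(O)(O)C(F)(F)F)Nc1c(F)cc(F)cc1F`), which reads 22200 nM, but compound 2 is a very different structure and no measured pair shows a comparable change.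

Compound 3 (`OC(c1c(F)c(F)c(-n2cc(-c3ccccc3)nn2)c(F)c1F)C(F)(F)F`) keeps the core of compound 1 and alters one place: hydrogen in place of hydroxy on a saturated chain carbon bound to an aromatic carbon, an oxygen on a saturated carbon and a saturated chain carbon. In words, hydrogen replaces hydroxy on a saturated chain carbon bound to an aromatic carbon, an oxygen on a saturated carbon and a saturated chain carbon, so that 2,2,2-trifluoro-1,1-dihydroxyethyl becomes 2,2,2-trifluoro-1-hydroxyethyl.

The expectation therefore rests on this single small edit and on compound 1, whose reading of > 100000 nM gives no sign of measurable activity to build on. No large move in either direction is expected, and the expected step, a number no higher from compound 1 to compound 3 (the limit leaves the size open), stays roughly within the scatter. Compound 3 may well end at the assay limit too. For compound 3 the estimated value is 100000 nM, with an expected range from 30000 nM to 300000 nM.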

Compound 3, half-maximal inhibitory concentration: > 100000 nM
Compound 3 ended at the assay's limit (the forecaster's own chance of this, stated with the estimate: 60%); the middle value sits exactly at the limit.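

Compound 1 and compound 3 both stand at a limit of the assay and not at a number, so no step between them can be read: the limit of > 100000 nM in this assay, at which 2 of the 3 values shown sit.

The compounds shown leave open whether changing 2,2,2-trifluoro-1,1-dihydroxyethyl to 2,2,2-trifluoro-1-hydroxyethyl makes any difference in this assay, and whether the shared core can give a measurable reading there.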